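Swapping the Bromophenyl Group for a Methylphenyl Group

The source may hold more compounds than are shown below. What is called first, only, known or untested is meant among the compounds shown, and "the series" means these compounds.

Compound 1 `Fc1ccc2nc(-c3ccccc3)nc(Nc3ccccc3)c2c1`: > 50000 nM
Compound 2 `Fc1cccc(-c2nc(Nc3ccccc3F)c3cc(F)ccc3n2)c1`: > 50000 nM
Compound 3 `Fc1cccc(-c2nc(Nc3ccc(Br)cc3)c3cc(F)ccc3n2)c1`: > 50000 nM

All three were tested in a functional assay on U2OS cells (Homo sapiens) for cytotoxicity, read by MTT assay, with a stated time of 48 h; a higher number here means a weaker inhibitor, a lower number a stronger inhibitor. Compound 1 gives only a limit of the assay, > 50000 nM. Compound 2 likewise gives only a limit, > 50000 nM. Compound 3 also stands at a limit, > 50000 nM, so no number is known for it, and the two other measured values are limits as well. Within the data shown here, the one comparison between compounds that differ in a single place, a step that the two limits leave unreadable from compound 2 to compound 3, cannot be read because of the limit of > 50000 nM in this assay, at which 3 of the 3 values shown sit.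

The next compound, compound 4 `Cc1cccc(Nc2nc(-c3cccc(F)c3)nc3ccc(F)cc23)c1`, differs from compound 3 in one place: 3-methylphenyl in place of 4-bromophenyl on a nitrogen on an aromatic ring. Among the measured compounds shown here, no measured step bears on this change in a readable way; the single step known stayed unreadable. Compound 3 shows only a limit, > 50000 nM, and that gives no ground to expect a measurable number after this change. Compound 4 is therefore expected to sit near 70000 nM, within a range of 30000 nM to 200000 nM, most likely reported again as a limit. The expected step that the limit leaves unreadable from compound 3 to compound 4 is thus none beyond the scatter.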

Compound 4, half-maximal inhibitory concentration: > 50000 nM
Compound 4 gave a limit, no number; the forecaster's own chance of this, stated with the estimate: 85%; the middle value lies beyond the limit too.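

Compound 4 also stands at a limit and not at a number, so neither the step from compound 3 to compound 4 nor the one from compound 2 to compound 4 can be read, because of this: the limit of > 50000 nM in this assay, at which 4 of the 4 values shown sit.

The compounds shown leave open whether any change to the shared core or its groups would give a real number in this assay.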